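Swapping the urea for an aryl amine on the thiazole nitrogen

The source may report more compounds than this note shows. Statements on the series, on what has been measured and on what is new or still open speak of the compounds shown alone.

Measured so far in a functional assay on WI-38 VA13 cells (Homo sapiens) for cytotoxicity; a higher number here means that more compound is needed for the effect, a lower number that less compound is needed:
compound 1 `O=C(O)CCC(=O)Nc1nc2ccc(NC(=O)c3c(Cl)cccc3Cl)cc2s1`, a limit, > 6.6 ug/mL
compound 2 `CC(C)NC(=O)Nc1nc2ccc(NC(=O)c3c(Cl)cccc3Cl)cc2s1`, 0.03 ug/mL
compound 3 `O=C(NCc1ccccc1)Nc1nc2ccc(NC(=O)c3c(Cl)cccc3Cl)cc2s1`, 0.15 ug/mL

Compound 3 gives the higher of the two real numbers here; its nearest neighbour is compound 2, as the step of a 5.0-fold higher number from compound 2 to compound 3 (0.70 log units; beyond the scatter) shows. For compound 1 only a limit is known, marked by the limit of > 6.6 ug/mL in this assay, at which 1 of the 3 values shown sits. Compound 4 `COc1cccc(Nc2nc3ccc(NC(=O)c4c(Cl)cccc4Cl)cc3s2)c1` changes compound 3 in one place: 3-methoxyphenyl in place of benzylcarbamoyl on a nitrogen on an aromatic ring. Within the data shown here, no measured step matches this change. The steps of an at least 220-fold lower number from compound 1 to compound 2 (2.34 log units; beyond the scatter) and an at least 44-fold lower number from compound 1 to compound 3 (1.64 log units; beyond the scatter) show that what sits on this nitrogen can shift the number strongly, while a 5.0-fold higher number from compound 2 to compound 3 (0.70 log units; beyond the scatter) was modest. Compound 4 is therefore expected to give 0.3 ug/mL, between 0.05 ug/mL and 2 ug/mL, a step of a 2.0-fold higher number from compound 3 to compound 4 (0.30 log units; within the scatter) in this assay.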

Compound 4, half-maximal effective concentration: > 7.2 ug/mL
Compound 4: only a limit was reported; the forecaster's own chance of this, stated with the estimate: 10%; middle value at least 24-fold (1.38 log units) from the limit.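

In this assay the swap to 3-methoxyphenyl on this nitrogen brings an at least 48-fold higher number from compound 3 to compound 4 (1.68 log units; beyond the scatter) and an at least 240-fold higher number from compound 2 to compound 4 (2.38 log units; beyond the scatter) as well, so the large shift is not tied to one carbamoyl group. Among these compounds, compound 4 carries no carboxylic acid, so the 2-carboxyethyl chain of compound 1 is not the only group here that ends in a limit. The result for compound 4 is a limit and not a number: the limit of > 7.2 ug/mL in this assay, at which 1 of the 4 values shown sits.

Compound 1 and compound 4 are both limits, and the step between them cannot be read. Also open, as far as these compounds go, is whether the shift follows the incoming ring or the lost carbonyl, which a plain phenyl or an acetyl on this nitrogen could help separate.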